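A few compounds are considered here, and "the series" means these few. Any claim that something is new, unique, unknown or untested is made for them only; others in the source may bear on it.

Measured so far:
compound 1 `C=C(C(=O)OCC)C(OC)c1ccccc1Cl`: > 100 uM
compound 2 `C=C(Cc1ccccc1Cl)C(=O)OCC`: > 100 uM
compound 3 `CCOC(=O)C(C)Cc1ccccc1Cl`: > 100 uM

In an ADME assay on THP-1 cells (Homo sapiens) for cytotoxicity, read by MTT assay, with a stated time of 72 h (on this read-out lower numbers stand for higher toxicity in this test and higher numbers for lower toxicity in this test), compound 3 gives > 100 uM, and this is a limit of the assay and not a number. Going by the values given here, the same holds for its two companions, and the series so far shows (the limit of > 100 uM in this assay, at which 3 of the 3 values shown sit). Compound 3 therefore has no readable place among them, and no order can be drawn.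

The next compound is compound 4 `CC(Cc1ccccc1Cl)C(=O)O`. The change from compound 3 is hydrogen in place of ethyl on an oxygen next to a carbonyl group. In words, it is hydrogen in place of ethyl on an oxygen next to a carbonyl group, or ethoxycarbonyl to carboxy.

Among the compounds with values here, no measured step covers this change. Within the data shown here, the only one recorded is a step that the two limits leave unreadable from compound 1 to compound 2, which concerns hydrogen in place of methoxy at another place and offers no size to carry over. The expectation thus rests on the limits alone, and no step beyond the scatter is expected in this assay, with the reading most likely to stay at the limit. The expected step is a step that the limit leaves unreadable from compound 3 to compound 4, an estimate with little behind it. For compound 4 the estimate is 150 uM, with an expected range from 60 uM to 350 uM.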

Compound 4, half-maximal toxic concentration: > 100 uM
Compound 4 gave a limit, no number (the forecaster's own chance of this, stated with the estimate: 80%); the middle value is on the limit's open side.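

In this assay compound 4 gives > 100 uM, which is a limit of the assay and not a number. Compound 3 also stands at a limit, so no step can be read between compound 3 and compound 4. The compounds shown leave open what toxic concentration any of them has, and whether any change among them alters it: the limit of > 100 uM in this assay, at which 4 of the 4 values shown sit.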